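The source may hold more compounds than are shown below. What is called first, only, known or untested is meant among the compounds shown, and "the series" means these compounds.

Of the compounds shown here, three have been measured in an ADME assay on HOS cells (Homo sapiens) for cytotoxicity, read by luminescence and ATP content, with a stated time of 48 h (a higher number here means that more compound is tolerated, a lower number that less compound is tolerated), so far.

- Compound 1 `COc1ccc2c(O)c(C(=O)NCc3ccc(F)cc3F)c(=O)n(O)c2n1` gives 12000 nM
- Compound 2 `O=C(NCc1ccc(F)cc1F)c1c(O)c2cc(CCCCCO)cnc2n(O)c1=O` gives > 250000 nM (a limit, not a number)
- Compound 3 `Nc1c(C(=O)NCc2ccc(F)cc2F)c(=O)n(O)c2ncc(CCCC3CCCCC3)cc12` gives 27400 nM

Of the two compounds with true numbers, compound 3 stands highest, and its gap to compound 1 lies beyond the usual scatter. The next compound, compound 4 `CN(C)CCCc1cnc2c(c1)c(N)c(C(=O)NCc1ccc(F)cc1F)c(=O)n2O`, carries dimethylamino in place of cyclohexyl on a saturated chain carbon, three bonds along the chain from an aromatic carbon, so that 3-cyclohexylpropyl becomes 3-(dimethylamino)propyl (dimethylamino in place of cyclohexyl on a saturated chain carbon, three bonds along the chain from an aromatic carbon). Among the compounds with values here, no measured pair isolates this change, so any expectation is rough. It leans on compound 2, whose chain also lacks a cyclohexyl and whose reading of > 250000 nM is a limit of the assay. An upward move is therefore expected, with the estimated step of a 3.3-fold higher number from compound 3 to compound 4 (0.52 log units; beyond the scatter) lying beyond the scatter. For compound 4 the estimated value is 90000 nM, with an expected range from 25000 nM to 250000 nM.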

Compound 4, half-maximal cytotoxic concentration: 5000 nM
The estimate for compound 4 lay 18-fold (1.26 log units) above the measured number, outside the stated range (below it).
By their numbers in this assay, from the lowest: compound 4; then compound 1; then compound 3. At a limit, above all of these: compound 2.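

Within the data shown here, this is the first step that changes one place only, and it runs downward: in this assay, dimethylamino in place of cyclohexyl on a saturated chain carbon, three bonds along the chain from an aromatic carbon, gives a 5.5-fold lower number from compound 3 to compound 4 (0.74 log units; beyond the scatter). At this position, then, the group on the chain bears on how much compound the cells tolerate, and removing the cyclohexyl does not by itself raise the number. The reading for compound 2 remains a limit, not a number, and it sets no size for this change: the limit of > 250000 nM in this assay, at which 1 of the 4 values shown sits.

From the compounds shown here alone, with a single pair, it stays open whether the lower number follows the added nitrogen or the lost ring. A morpholine, a hydroxyl or a carboxylic acid on the same chain carbon, or a longer chain carrying dimethylamino, could separate the two.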